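Swapping the Methoxypyrimidinyl Ring: Expected Exposure of Compound 4

A few compounds are considered here, and "the series" means these few. Any claim that something is new, unique, unknown or untested is made for them only; others in the source may bear on it.

Measured compounds:
Compound 1, `COc1cc(OCc2csc(-c3ccc(C(F)(F)F)cc3)n2)c2cc(-c3cn4nc(OC)sc4n3)oc2c1`, gives 726 ng.h/mL in an ADME assay on the whole organism (Rattus norvegicus), at a dose of 2 mg/kg by the oral route; a higher number here means more compound in the circulation at the dose given, a lower number less compound in the circulation.
Compound 2, `COc1cc(OCc2cccc(-c3cnc(OC)nc3)c2)c2cc(-c3cn4nc(OC)sc4n3)oc2c1`, gives 1030 ng.h/mL in this assay.
Compound 3, `COc1cc(OCc2csc(-c3ccc(S(C)(=O)=O)cc3)n2)c2cc(-c3cn4nc(OC)sc4n3)oc2c1`, gives 148 ng.h/mL in this assay.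

Compound 2 has the highest number of the three. Its gap to compound 1 is within the usual scatter, so the two cannot be told apart on these data; its gap to compound 3 lies beyond the scatter. Within the data shown here, the one step measured between close neighbours, a 4.9-fold lower number from compound 1 to compound 3 (0.69 log units; beyond the scatter), concerns a group on another ring of the shared core.

Compound 4, `COc1ccc(-c2cccc(COc3cc(OC)cc4oc(-c5cn6nc(OC)sc6n5)cc34)c2)nc1`, is the compound still to be measured. It differs from compound 2 in one place: 5-methoxypyridin-2-yl in place of 2-methoxypyrimidin-5-yl on an aromatic carbon. Among the measured compounds shown here, no measured step touches this kind of change; the step from compound 1 to compound 3 swaps a different group on a different ring and offers no guide here. Without such a guide, the change to compound 4 is expected to be a 1.1-fold lower number from compound 2 to compound 4 (0.06 log units; within the scatter), not beyond the scatter. Compound 4 is therefore estimated at 900 ng.h/mL in this assay, with a range from 350 ng.h/mL to 2300 ng.h/mL.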

Compound 4, area under the concentration-time curve: 1700 ng.h/mL
Beside the measured number, compound 4's estimate is 1.9-fold (0.28 log units) below it; the range from low to high includes it.
By their numbers in this assay, from the lowest: compound 3; then compounds 1, 2 and 4 (each within the scatter of the next, the first and the last beyond it).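

On the six-membered aromatic ring of carbon only, 5-methoxypyridin-2-yl in place of 2-methoxypyrimidin-5-yl gives (a 1.7-fold higher number from compound 2 to compound 4 (0.22 log units; within the scatter)), so in (this assay) compound 2 and compound 4 cannot be told apart. Among these compounds, the earlier compounds held no step at this position, and this pair is the first to show that a ring with 1 hetero atom and a ring with 2 hetero atoms can stand here with a difference no larger than the usual variation between repeat measurements. Nothing measured here offers a reason for this result.

Going by these compounds, whether this holds for other groups at this position remains open: a carboxylic acid or an amine such as morpholine could give a very different number. On these data alone, it is also open whether the methoxy group on the new ring matters, since neither compound shows that ring with a hydrogen or a longer chain such as ethoxy in its place.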